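Swapping the aryl arm on the cyanopyridinone core

This account rests on a few compounds, and the source may have more. Where it says the series, first, only, none or still open, it means among the compounds named here.

The series shares a single core, seen in compound 1 `Cc1cc(O)c(C(C)C)cc1-c1cc(-c2ccccc2)c(C#N)c(=O)[nH]1`, which carries a phenyl on the aromatic carbon in question. In a functional assay for inhibition, tested at 60 ug/mL (on this read-out lower numbers stand for a weaker effect and higher numbers for a stronger effect at the one concentration tested), compound 1 gives 34%. Compound 2 `Cc1cc(O)c(C(C)C)cc1-c1cc(-c2ccco2)c(C#N)c(=O)[nH]1` replaces that phenyl with furan-2-yl, and in this assay compound 2 gives 55.2%. Going by the values given here, this is the higher of the two numbers recorded so far, with a number 21.2 percentage points higher from compound 1 to compound 2 (beyond the scatter) being the only measured step in this set.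

Compound 3 `Cc1cc(O)c(C(C)C)cc1-c1cc(-c2ccccc2[N+](=O)[O-])c(C#N)c(=O)[nH]1` is not yet measured. Its change from compound 2 is 2-nitrophenyl in place of furan-2-yl on an aromatic carbon. Among the compounds with values here, the single measured step bears on it only indirectly: going from compound 2 back toward a six-membered carbon ring reverses the direction of a number 21.2 percentage points higher from compound 1 to compound 2 (beyond the scatter), while the nitro group is untested, so no measured step shows its own effect. On that basis compound 3 is expected to sit between the two known values, nearer compound 1, with a step of a number 13.2 percentage points lower from compound 2 to compound 3 (beyond the scatter).

Compound 3 is therefore estimated at 42%, with a range from 22% to 62%.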

Compound 3, a percentage reported as inhibition, at one concentration (the size of the read-out at that concentration, not a potency): 31%
Estimate against measurement, compound 3: 11 percentage points above; the range from low to high includes it.
By their numbers in this assay, from the lowest: compounds 3 and 1 (each within the scatter of the next); then compound 2.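

In this assay, going by these compounds alone, the new compound gives the first reading of a substituent on the six-membered aromatic ring at this position: adding nitro to the phenyl moves the number by only a number 3 percentage points lower from compound 1 to compound 3 (within the scatter), so this change shows no effect that can be told from the scatter. The step of a number 24.2 percentage points lower from compound 2 to compound 3 (beyond the scatter) is a second measured gap of this kind, and among the three compounds the two carrying a six-membered aromatic ring of carbon only stay together, while furan-2-yl, the one five-membered aromatic ring with a hetero atom, stands apart with the highest number and no compound shown goes against this. The data offer no measured explanation for why furan-2-yl differs from either six-membered ring.

The compounds shown leave open whether the higher number belongs to the five-membered ring as such or to its oxygen, which a thiophen-2-yl would begin to separate. They also leave open whether a phenyl carrying an amine or a carboxylic acid in place of the nitro would stay with compound 1 and compound 3 or move toward compound 2.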